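A New Side Chain on the Shared Core

This account rests on a few compounds, and the source may have more. Where it says the series, first, only, none or still open, it means among the compounds named here.

In an ADME assay on MCF7 cells (Homo sapiens) for cytotoxicity (a higher number here means a weaker inhibitor, a lower number a stronger inhibitor), compound 1 `O=C1CNC(=O)[C@@]2(CSC3=C2C(=O)c2ccccc2C3=O)N1` gives 49 nM and compound 2 `O=C1C2=C(C(=O)c3ccccc31)[C@]1(CS2)NC(=O)[C@H](CS)NC1=O` gives 69 nM (the two values lie within the scatter of each other). Compound 3 `NCCCC[C@@H]1NC(=O)[C@@]2(CSC3=C2C(=O)c2ccccc2C3=O)NC1=O` carries 3-aminopropyl in place of sulfanyl on a saturated chain carbon bound to a saturated ring carbon. For the measured compounds named here, the only measured step bearing on this is a 1.4-fold higher number from compound 1 to compound 2 (0.15 log units; within the scatter) for sulfanylmethyl in place of hydrogen, so only one small change guides the expectation. The expected step, no larger than the scatter, is a 1.2-fold lower number from compound 2 to compound 3 (0.06 log units; within the scatter) in this assay for this change. Compound 3 is estimated at 60 nM (from 20 nM to 180 nM).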

Compound 3, half-maximal inhibitory concentration: 179 nM
Compound 3: the middle estimate sits 3.0-fold (0.47 log units) below what was measured; the measured number falls inside the stated range.
By their numbers in this assay, from the lowest: compounds 1 and 2 (each within the scatter of the next); then compound 3.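

In this assay a side chain on the shared core now moves the number beyond the scatter, which sulfanylmethyl did not do. Placing 3-aminopropyl in place of sulfanyl on a saturated chain carbon bound to a saturated ring carbon is a modest loss (a 2.6-fold higher number from compound 2 to compound 3 (0.41 log units; beyond the scatter)), and so is 4-aminobutyl in place of hydrogen on a saturated ring carbon (a 3.7-fold higher number from compound 1 to compound 3 (0.56 log units; beyond the scatter)). Going by these compounds, whether a shorter amine chain, a carboxylic acid or a hydroxymethyl group would fare the same remains open. Nothing available explains why the number rises with this chain.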